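Compound 4: methyl in place of methylsulfanyl

The source may hold more compounds than are shown below. What is called first, only, known or untested is meant among the compounds shown, and "the series" means these compounds.

Compound 1 `CSc1ncnc2c1c(-c1ccoc1)cn2[C@@H]1O[C@H](CO)[C@@H](O)[C@H]1O`: 5390 nM
Compound 2 `CSc1ncnc2c1c(-c1cccs1)cn2[C@@H]1O[C@H](CO)[C@@H](O)[C@H]1O`: 1960 nM
Compound 3 `CSc1ncnc2c1c(-c1ccsc1)cn2[C@@H]1O[C@H](CO)[C@@H](O)[C@H]1O`: > 20000 nM

In a functional assay on HeLa S3 cells (Homo sapiens) for antiproliferative activity, read by XTT assay, with a stated time of 72 h (a higher number here means a weaker inhibitor, a lower number a stronger inhibitor), compound 1 holds the higher of the two true numbers, with a 2.8-fold lower number from compound 1 to compound 2 (0.44 log units; beyond the scatter). The entry for compound 3 is a limit of the assay and not a number.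

Compound 4 `Cc1ncnc2c1c(-c1ccoc1)cn2[C@@H]1O[C@H](CO)[C@@H](O)[C@H]1O` keeps the furan-3-yl group of compound 1 and carries methyl in place of methylsulfanyl on an aromatic carbon.

The measured steps all exchange the furan-3-yl or thiophene group, and none touches the methylsulfanyl: a 2.8-fold lower number from compound 1 to compound 2 (0.44 log units; beyond the scatter), an at least 3.7-fold higher number from compound 1 to compound 3 (0.56 log units; beyond the scatter) and an at least 10-fold higher number from compound 2 to compound 3 (1.00 log units; beyond the scatter). They bear on the new change only indirectly, showing that a single exchange can move this series by a modest amount or more. Going by these compounds, they give no direction, so no step beyond the scatter is expected, although a wide range stays open on either side.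

The expected step is a 1.1-fold lower number from compound 1 to compound 4 (0.03 log units; within the scatter).

Compound 4 is estimated at 5000 nM, with an expected range from 1000 nM to 20000 nM.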

Compound 4, half-maximal inhibitory concentration: > 20000 nM
Compound 4: no number, only a limit; the forecaster's own chance of this, stated with the estimate: 25%; at least 4.0-fold (0.60 log units) between middle value and limit.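

Among these compounds, exchanging methylsulfanyl for methyl with the furan-3-yl group held fixed gives an at least 3.7-fold higher number from compound 1 to compound 4 (0.56 log units; beyond the scatter) in this assay and so shows that this position, untouched by the earlier steps, also moves the read-out beyond the scatter. The step has a direction the earlier exchanges could not give: activity falls when methyl replaces methylsulfanyl on this aromatic carbon. Compound 4 gives only a limit of the assay and not a number, and the full size of the step stays unknown because the reading ends there: the limit of > 20000 nM in this assay, at which 2 of the 4 values shown sit.

Going by these compounds, whether the loss is specific to methyl or follows any replacement of methylsulfanyl stays open, as does the outcome with an amine, a methoxy group or a longer alkylsulfanyl chain at this position. Also open, on these data alone, is whether the same exchange carries over to the thiophen-2-yl group of compound 2.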